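The source may report more compounds than this note shows. Statements on the series, on what has been measured and on what is new or still open speak of the compounds shown alone.

The three measured compounds, each tested in a functional assay on the whole organism (strain Wistar) for inhibition, with Rattus norvegicus as the target, read by paw edema, with stated times of 60 min and 1 h, at a dose of 100 mg/kg by the oral route; on this read-out lower numbers stand for less inhibition and higher numbers for more inhibition at the one dose given (going by the name of the read-out):

Compound 1, `CCNC(=O)CC1CCc2cc(OC)c(OC)cc21`, gives 15.6%.
Compound 2, `COc1cc2c(cc1OC)C(CC(=O)NC(C)C)CC2`, gives 31.3%.
Compound 3, `CCCCCCNC(=O)CC1CCc2cc(OC)c(OC)cc21`, gives 47.6%.

Compound 3 stands highest of the three, beyond the scatter above both others. Every measured step alters the group on the amide nitrogen: a number 15.7 percentage points higher from compound 1 to compound 2 (beyond the scatter), a number 32 percentage points higher from compound 1 to compound 3 (beyond the scatter) and a number 16.3 percentage points higher from compound 2 to compound 3 (beyond the scatter), so larger groups there went with higher numbers. Compound 4, `COc1cc2c(cc1OC)C(CC(=O)NCc1ccccc1)CC2`, differs from compound 3 by phenyl in place of pentyl on a saturated chain carbon bound to an amide-type nitrogen. For the measured compounds named here, the entering group is about as large as the leaving one, but no measured compound carries an aromatic ring on that nitrogen, so the precedent is indirect. The expected step is a number 5.6 percentage points lower from compound 3 to compound 4 (within the scatter), within the scatter. Compound 4 is therefore estimated at 42%, between 22% and 62%.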

Compound 4, a percentage reported as inhibition, in the whole organism at one dose (the size of the read-out at that dose, not a potency): 18.8%
Compound 4: the middle estimate sits 23.2 percentage points above what was measured, and the stated range ends above it.
By their numbers in this assay, from the lowest: compounds 1 and 4 (each within the scatter of the next); then compound 2; then compound 3.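

The earlier rise with larger groups on the amide nitrogen does not extend to benzyl. Phenyl in place of pentyl gives a number 28.8 percentage points lower from compound 3 to compound 4 (beyond the scatter), benzyl in place of isopropyl gives a number 12.5 percentage points lower from compound 2 to compound 4 (beyond the scatter), and phenyl in place of methyl gives a number 3.2 percentage points higher from compound 1 to compound 4 (within the scatter), so compound 4 goes against that trend and an aromatic ring at this place does not act like a saturated chain. Nothing available explains this difference.

Still open, as far as these compounds go, is whether the ring itself or its short link to the nitrogen matters. A cyclohexylmethyl or a phenylethyl group on that nitrogen would help separate the two.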